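The source may hold more compounds than are shown below. What is called first, only, known or untested is meant among the compounds shown, and "the series" means these compounds.

Measured so far in an assay on isolated protein for inhibition of long-chain fatty acid transport protein 1 (Homo sapiens), read by scintillation counting, with a stated time of 20 min; a higher number here means a weaker inhibitor, a lower number a stronger inhibitor:

- Compound 1, `O=C(CN1CCN(C2CCCCC2)CC1)Nc1nc2c(s1)CCCC2`, gives > 1000 nM in this assay, a limit of the assay rather than a number.
- Compound 2, `O=C(CN1CCN(c2ccncc2)CC1)Nc1nc2c(s1)CCCC2`, gives > 1000 nM in this assay, likewise a limit.
- Compound 3, `Cc1ccc(N2CCN(CC(=O)Nc3nc4c(s3)CCCC4)CC2)cc1`, gives 250 nM in this assay.

Among the compounds with values here, compound 3 therefore holds the only actual number among the three; the other two sit at the limit of > 1000 nM in this assay, at which 2 of the 3 values shown sit. Against those limits, the step of an at least 4.0-fold lower number from compound 1 to compound 3 (0.60 log units; beyond the scatter) and the step of an at least 4.0-fold lower number from compound 2 to compound 3 (0.60 log units; beyond the scatter) are both read as at least modest gains, while the step that the two limits leave unreadable from compound 1 to compound 2 cannot be sized.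

Compound 4, `O=C(CN1CCN(c2cccnc2)CC1)Nc1nc2c(s1)CCCC2`, differs from compound 3 in one place: pyridin-3-yl in place of 4-methylphenyl on an amine nitrogen in a ring. The nearest measured guide is the step from compound 2 to compound 3, in which a pyridin-4-yl gave way to a 4-methylphenyl and the number fell at least modestly. Compound 4 runs that exchange backwards, though with the nitrogen at a different position of the ring, so a rise of the number, likely back toward the limit, is expected. The step of a 3.6-fold higher number from compound 3 to compound 4 (0.56 log units; beyond the scatter) is the expected size. Compound 4 is estimated at 900 nM in this assay, with a range of 350 nM to 3000 nM.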

Compound 4, half-maximal inhibitory concentration: > 1000 nM
Compound 4 gave a limit, no number (the forecaster's own chance of this, stated with the estimate: 50%); at least 1.1-fold (0.04 log units) between middle value and limit.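

In this assay, the change from 4-methylphenyl to pyridin-3-yl on this amine nitrogen in a ring gives an at least 4.0-fold higher number from compound 3 to compound 4 (0.60 log units; beyond the scatter), so a second pyridine placed here also fails to keep the activity of compound 3. Compound 4 gives a limit rather than a number, and so does compound 2, which shows that moving the ring nitrogen from pyridin-4-yl to pyridin-3-yl brings no readable return; the steps among compound 1, compound 2 and compound 4 cannot be read, since each joins two limits. Within the data shown here, compound 3 remains the only compound here with an actual number, and the limit now holds most of the set: the limit of > 1000 nM in this assay, at which 3 of the 4 values shown sit.

On these data alone, compound 4 swaps two things at once, losing the methyl group and adding a ring nitrogen, so it remains open which of these goes with the higher number, and a plain phenyl group at this position would separate the two. As far as these compounds go, how far a 4-chlorophenyl or 4-methoxyphenyl group would move the number from that of compound 3 also stays open.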